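Isopropylamino to dimethylamino on the sulfonyl sulfur

The source may hold more compounds than are shown below. What is called first, only, known or untested is meant among the compounds shown, and "the series" means these compounds.

Compound 2 (`Cc1ccc(S(=O)(=O)NC(C)C)cc1C#Cc1cc(Cl)ccc1OCC(=O)O`) gives < 10 mL.min-1.g-1 in an in vitro ADME assay on microsomes from liver (Homo sapiens) for metabolic stability, read by LC-MS, tested at 1 uM (a lower number here means slower removal, a higher number faster removal of the compound), as a limit of the assay, not a number. Compound 1 (`COCCNS(=O)(=O)c1ccc(C)c(C#Cc2cc(Cl)ccc2OCC(=O)O)c1`) gives < 10 mL.min-1.g-1 in this assay as a limit too. Going by the values given here, the one measured step bearing on the change is a step that the two limits leave unreadable from compound 1 to compound 2 and it offers no size. Compound 3 (`Cc1ccc(S(=O)(=O)N(C)C)cc1C#Cc1cc(Cl)ccc1OCC(=O)O`) differs from compound 2 by dimethylamino in place of isopropylamino on a sulfonyl sulfur in one place: dimethylamino in place of isopropylamino on a sulfonyl sulfur. Among the compounds with values here, the only evidence is the limit of < 10 mL.min-1.g-1 in this assay, at which 2 of the 2 values shown sit, and so no shift beyond the scatter is expected. The expected step is a step that the limit leaves unreadable from compound 2 to compound 3 in this assay with no direction favoured. Estimated for compound 3: 7 mL.min-1.g-1 (range 3 mL.min-1.g-1 to 16 mL.min-1.g-1).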

Compound 3, intrinsic clearance in microsomes: < 10 mL.min-1.g-1
Compound 3: only a limit was reported; the forecaster's own chance of this, stated with the estimate: 75%; the middle value does not contradict the limit.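

No step among compound 1, compound 2 and compound 3 can be read in this assay, each value being a limit of the assay and not a number: the limit of < 10 mL.min-1.g-1 in this assay, at which 3 of the 3 values shown sit.

The compounds shown leave open whether these three differ in intrinsic clearance in microsomes at all.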